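The source may report more compounds than this note shows. Statements on the series, on what has been measured and on what is new or still open speak of the compounds shown alone.

Working notes on the series. In a functional assay on MCF7 cells (Homo sapiens) for cytotoxicity, read by MTT assay (on this read-out higher numbers stand for weaker inhibition and lower numbers for stronger inhibition), compound 1 `Oc1ccc(CN(Cc2ccccc2)Cc2ccc(O)c3ncccc23)c2cccnc12` gives 97 nM, compound 2 `Oc1ccc(CN(Cc2cccc(C(F)(F)F)c2)Cc2ccc(O)c3ncccc23)c2cccnc12` gives 30 nM and compound 3 `Oc1ccc(CN(Cc2cc(C(F)(F)F)cc(C(F)(F)F)c2)Cc2ccc(O)c3ncccc23)c2cccnc12` gives 38 nM. Compound 2 therefore stands level with compound 3 at the low end of the three numbers, clear of compound 1.

Compound 4 `Oc1ccc(CN(Cc2cccs2)Cc2ccc(O)c3ncccc23)c2cccnc12` is not yet measured. Its difference from compound 2 is thiophen-2-yl in place of 3-(trifluoromethyl)phenyl on a saturated chain carbon bound to an amine nitrogen.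

Within the data shown here, two measured steps bear on this change, both of them trifluoromethyl in place of hydrogen on an aromatic carbon. The first, a 3.2-fold lower number from compound 1 to compound 2 (0.51 log units; beyond the scatter), is modest and beyond the scatter. The second, a 1.3-fold higher number from compound 2 to compound 3 (0.10 log units; within the scatter), stays within the scatter. Among the measured compounds shown here, compound 4 carries no trifluoromethyl, which makes compound 1 at 97 nM the nearest reference, although no thiophen-2-yl compound has been measured and the ring exchange itself has no direct precedent.

A modest move to a higher number is therefore expected in this assay, close in size to the first step read in reverse. The expected step is a 2.5-fold higher number from compound 2 to compound 4 (0.40 log units; beyond the scatter). Compound 4 is estimated at 75 nM, with an expected range of 30 nM to 190 nM.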

Compound 4, half-maximal inhibitory concentration: 35 nM
Estimate against measurement, compound 4: 2.1-fold (0.33 log units) above, within the range that was stated.
By their numbers in this assay, from the lowest: compounds 2, 4 and 3 (each within the scatter of the next); then compound 1.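

In this assay, among these compounds, thiophen-2-yl in place of phenyl on a saturated chain carbon bound to an amine nitrogen gives a 2.8-fold lower number from compound 1 to compound 4 (0.44 log units; beyond the scatter), so the group at this place can move the number beyond the scatter with no trifluoromethyl present, which the earlier steps, both trifluoromethyl in place of hydrogen, could not show. Thiophen-2-yl in place of 3-(trifluoromethyl)phenyl gives a 1.2-fold higher number from compound 2 to compound 4 (0.07 log units; within the scatter), so two different aromatic rings, one of carbon only and one five-membered with a sulfur atom, stand level at this place, and the number at this level is not tied to trifluoromethyl. Nothing on hand accounts for this match between the two rings.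

The compounds shown leave open whether a furan-2-yl ring, a pyridin-2-yl ring or a saturated cyclohexyl ring at this place would hold the same level, and whether a plain methyl or a longer alkyl chain would do so without any ring. They also leave open whether a trifluoromethyl on the thiophen-2-yl ring would repeat a 3.2-fold lower number from compound 1 to compound 2 (0.51 log units; beyond the scatter) seen on the phenyl ring or would leave the number in place, as in a 1.3-fold higher number from compound 2 to compound 3 (0.10 log units; within the scatter).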